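Thiophene in Place of Indole on the Hydrazone

The source may report more compounds than this note shows. Statements on the series, on what has been measured and on what is new or still open speak of the compounds shown alone.

Measured compounds:
compound 1 `COc1cc2c(Oc3ccc(NC(=O)N/N=C/c4ccc(F)cc4Cl)cc3F)ccnc2cc1OCCCN1CCCCC1` — 130 nM
compound 2 `COc1cc2c(Oc3ccc(NC(=O)N/N=C/c4cc5ccccc5[nH]4)cc3F)ccnc2cc1OCCCN1CCCCC1` — 780 nM

In a functional assay on A549 cells (Homo sapiens) for cytotoxicity, read by MTT assay, with a stated time of 72 h (a lower number here means a stronger inhibitor, a higher number a weaker inhibitor), compound 2 stands highest of the two, with compound 1 giving the lower number. Within the data shown here, the one measured step is a 6.0-fold higher number from compound 1 to compound 2 (0.78 log units; beyond the scatter). Compound 3 `COc1cc2c(Oc3ccc(NC(=O)N/N=C/c4cccs4)cc3F)ccnc2cc1OCCCN1CCCCC1` carries the change (thiophen-2-yl in place of 1H-indol-2-yl on a carbon with a double bond to nitrogen). Among the measured compounds shown here, no measured step covers a thiophen-2-yl group, so the expectation rests on compound 2 alone, whose indol-2-yl group gave 780 nM after the rise from compound 1. Compound 3 is expected to show a modest fall, a 2.2-fold lower number from compound 2 to compound 3 (0.35 log units; beyond the scatter), with an estimate of 350 nM and a range from 120 nM to 1000 nM.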

Compound 3, half-maximal inhibitory concentration: 790 nM
Compound 3: middle estimate off by 2.3-fold (0.35 log units), on the low side; measured number inside the range.
By their numbers in this assay, from the lowest: compound 1; then compounds 2 and 3 (each within the scatter of the next).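

In this assay the step stands at a 1.0-fold higher number from compound 2 to compound 3 (0.01 log units; within the scatter) and so shows that, on this carbon with a double bond to nitrogen, the indole's six-membered aromatic ring and its hydrogen-bond donor can go without a readable effect. The 2-chloro-4-fluorophenyl group also stays ahead of thiophen-2-yl, at a 6.1-fold higher number from compound 1 to compound 3 (0.78 log units; beyond the scatter) in the same read-out. Nothing shown gives a reason for these results. From the compounds shown here alone, whether an unsubstituted phenyl, furan-2-yl or pyridin-2-yl group would match compound 1 remains open, as does what the chlorine and the fluorine each contribute.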